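Oxime ether chain length and antiproliferative potency

This account rests on a few compounds, and the source may have more. Where it says the series, first, only, none or still open, it means among the compounds named here.

Measured compounds:
compound 1 `CCCCCCCCCCCCO/N=C(\CCCCCC)c1cc(OC)c2c(c1OC)C(=O)C=CC2=O`: 0.193 ug/mL
compound 2 `COc1cc(/C=N/OCc2ccccc2)c(OC)c2c1C(=O)C=CC2=O`: 0.264 ug/mL
compound 3 `CCCCCCCO/N=C(\CCCCCC)c1cc(OC)c2c(c1OC)C(=O)C=CC2=O`: 0.162 ug/mL

In a functional assay on L1210 cells (Mus musculus) for antiproliferative activity (a higher number here means that more compound is needed for the effect, a lower number that less compound is needed), compound 2 gives the highest of the three numbers, yet its gaps to compound 1 and to compound 3 both lie within the scatter, so no order among the three can be claimed. Compound 4 `CCCCCCCCCO/N=C/c1cc(OC)c2c(c1OC)C(=O)C=CC2=O` has not yet been measured; it differs from compound 2 by octyl in place of phenyl on a saturated chain carbon bound to an oxygen. Within the data shown here, the one measured step that bears on a change in the chain attached to that oxygen is a 1.2-fold lower number from compound 1 to compound 3 (0.08 log units; within the scatter), where a shortening of the chain on the oxygen left the number essentially unchanged. Compounds 1 and 3 carry long alkyl chains on the oxygen and sit close to compound 2, which carries the benzyl group. On this basis compound 4 is expected to show no step beyond the scatter in this assay, with a step of a 1.3-fold lower number from compound 2 to compound 4 (0.12 log units; within the scatter). Compound 4 is therefore estimated at 0.2 ug/mL, within a range from 0.1 ug/mL to 0.4 ug/mL.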

Compound 4, concentration for half-maximal effect: 0.19 ug/mL
Beside the measured number, compound 4's estimate is 1.1-fold (0.02 log units) above it; the measured number falls inside the stated range.
By their numbers in this assay, from the lowest: compounds 3, 4, 1 and 2 (each within the scatter of the next).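

In this assay, octyl in place of phenyl on a saturated chain carbon bound to an oxygen gives a 1.4-fold lower number from compound 2 to compound 4 (0.14 log units; within the scatter), so the number does not separate the two compounds. The earlier step between compound 1 and compound 3 exchanged only one alkyl chain for another, whereas this step removes a six-membered aromatic ring of carbon and puts an open chain in its place, and even this change of kind stays within the scatter in this assay. Nothing shown gives a reason for this result.

From the compounds shown here alone, what remains open is whether a group of another kind at this place, such as an amine or a carboxylic acid at the end of the chain, would give a step beyond the scatter. A much shorter chain, such as methyl, is equally undecided by these compounds.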